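Imidazole-nitrogen substituent in a vitamin D receptor antagonist series

The compounds below may be only part of what the source reports. "The series", "measured", "known", "first", "only" and "open" are said of these compounds alone.

Measured compounds:
compound 1 `CC(C)c1onc(-c2c(Cl)cccc2Cl)c1COc1ccc(-c2nc3cc(C(=O)O)ccc3n2C)cc1`, 4410 nM
compound 2 `CC(=O)N1CCC(n2c(-c3ccc(OCc4c(-c5c(Cl)cccc5Cl)noc4C(C)C)cc3)nc3ccc(C(=O)O)cc32)CC1`, > 10000 nM
compound 3 `CCC(CC)n1c(-c2ccc(OCc3c(-c4c(Cl)cccc4Cl)noc3C(C)C)cc2Cl)nc2ccc(C(=O)O)cc21`, 1010 nM

In an assay on HEK-293T cells for antagonist activity at vitamin D3 receptor (Homo sapiens), read by a luciferase reporter, with a stated time of 24 h (on this read-out higher numbers stand for weaker inhibition and lower numbers for stronger inhibition), compound 1 gives 4410 nM. Compound 3, which carries pentan-3-yl on the same ring nitrogen together with a chloro on the phenyl ring, gives 1010 nM in this assay. Compound 2 is the odd one out: its value in this assay is a limit only, > 10000 nM, so no number is known for it. It therefore stands at the weak end of the three values shown, at the limit of > 10000 nM in this assay, at which 1 of the 3 values shown sits.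

Compound 4 `CC(C)c1onc(-c2c(Cl)cccc2Cl)c1COc1ccc(-c2nc3ccc(C(=O)O)cc3n2C2CCCCC2)cc1` has not yet been measured in this assay. It differs from compound 2 in one place: cyclohexyl in place of 1-acetylpiperidin-4-yl on an aromatic nitrogen.

Within the data shown here, no step between measured compounds covers this change directly. The two carbocyclic or branched alkyl substituents in compounds 1 and 3 both give measurable numbers, while the 1-acetylpiperidin-4-yl compound 2 gives only a limit. On that basis compound 4 is expected to return a number rather than a limit, with a step of an at least 5.0-fold lower number from compound 2 to compound 4 (0.69 log units; beyond the scatter) toward stronger inhibition, beyond the usual scatter. The estimate for compound 4 in this assay is 2000 nM, within 700 nM to 7000 nM.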

Compound 4, half-maximal inhibitory concentration: 1450 nM
Compound 4: the middle estimate sits 1.4-fold (0.14 log units) above what was measured, within the range that was stated.
By their numbers in this assay, from the lowest: compounds 3 and 4 (each within the scatter of the next); then compound 1. At a limit, above all of these: compound 2.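

Cyclohexyl in place of 1-acetylpiperidin-4-yl on an aromatic nitrogen gives, in this assay, an at least 6.8-fold lower number from compound 2 to compound 4 (0.83 log units; beyond the scatter), the first step in the series that isolates this position. Compound 2 is held at a limit, so the step has a floor and no known full size: the limit of > 10000 nM in this assay, at which 1 of the 4 values shown sits. The change removes the ring hetero atom and the hydrogen-bond acceptor together, and this one step cannot separate their contributions.

A free piperidine amine or a tetrahydropyranyl ring at this position would help separate the acetyl group from the ring hetero atom. Compound 1 and compound 3 each differ from compound 4 in more than one place, so the effect of substituent size on this nitrogen remains unresolved.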